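Dimethyl substitution on the acetylpiperazine of compound 3

The source may hold more compounds than are shown below. What is called first, only, known or untested is meant among the compounds shown, and "the series" means these compounds.

Measured compounds: compound 1 `CC(=O)N1C(C)CN(c2nc3c(c(-c4ccccc4C)n2)C(=O)N(Cc2cc(C(F)(F)F)cc(C(F)(F)F)c2)C[C@@H](C)CO3)CC1C` 52.9 nM; compound 2 `Cc1ccccc1-c1ncnc2c1C(=O)N(Cc1cc(C(F)(F)F)cc(C(F)(F)F)c1)CCCO2` 11.6 nM; compound 3 `CC(=O)N1CCN(c2nc3c(c(-c4ccccc4C)n2)C(=O)N(Cc2cc(C(F)(F)F)cc(C(F)(F)F)c2)CCCO3)CC1` 0.105 nM.

In a functional assay on ileum for antagonist activity at Substance-P receptor (Cavia porcellus) (a higher number here means a weaker inhibitor, a lower number a stronger inhibitor), compound 3 stands lowest of the three; compound 2 is nearest and compound 1 furthest. Compound 4 `CC(=O)N1C(C)CN(c2nc3c(c(-c4ccccc4C)n2)C(=O)N(Cc2cc(C(F)(F)F)cc(C(F)(F)F)c2)CCCO3)CC1C` differs from compound 3 in one place: a group of 11 heavy atoms (8 carbon, 2 nitrogen, 1 oxygen; one six-membered non-aromatic ring with 2 hetero atoms) in place of a group of 9 heavy atoms (6 carbon, 2 nitrogen, 1 oxygen; one six-membered non-aromatic ring with 2 hetero atoms), on an aromatic carbon, between two ring nitrogen atoms. Among the compounds with values here, the only single step measured, a 110-fold lower number from compound 2 to compound 3 (2.04 log units; beyond the scatter), concerns adding the acetylpiperazine, not methylating it. Compound 1, which carries the same dimethylated group together with a second change on the chain, gives a far higher number than compound 3, so part of that gap is expected here. Compound 4 is therefore expected to lose potency, a 29-fold higher number from compound 3 to compound 4 (1.46 log units; beyond the scatter), with an estimated value of 3 nM (range 0.3 nM to 30 nM).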

Compound 4, antagonist equilibrium constant: 0.679 nM
Compound 4: middle estimate off by 4.4-fold (0.65 log units), on the high side; the measured number falls inside the stated range.
By their numbers in this assay, from the lowest: compound 3; then compound 4; then compound 2; then compound 1.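

In this assay, the two added methyl groups on the acetylpiperazine cost potency (a 6.5-fold higher number from compound 3 to compound 4 (0.81 log units; beyond the scatter)), yet the dimethylated group still keeps much of the gain at this aromatic carbon (a 17-fold lower number from compound 2 to compound 4 (1.23 log units; beyond the scatter)). Removing the methyl on the saturated ring carbon from compound 1 then has a large effect of its own (a 78-fold lower number from compound 1 to compound 4 (1.89 log units; beyond the scatter)), so the weakness of compound 1 does not rest on the piperazine methyl groups alone. No measurement here accounts for either shift. Open, as far as these compounds go, is how a morpholine or a free piperazine amine would fare at this position.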